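Swapping the Group on the Saturated Ring Carbon

The source may hold more compounds than are shown below. What is called first, only, known or untested is meant among the compounds shown, and "the series" means these compounds.

In a functional assay on Ehrlich cells (Mus musculus) for cytotoxicity, read by trypan blue exclusion, with a stated time of 2 h, tested at 50 ug/mL (a lower number here means a weaker effect, a higher number a stronger effect of the compound at the concentration tested), the three measured compounds gave these results:

Compound 1 `N#CC1=C(N)N(c2ccc(S(N)(=O)=O)cc2)C2=C(CCCC2)C1/C=C/c1ccccc1`: 90%
Compound 2 `N#CC1=C(N)N(c2ccc(S(N)(=O)=O)cc2)C2=C(CCCC2)C1c1ccc([N+](=O)[O-])cc1`: 10%
Compound 3 `N#CC1=C(N)N(c2ccc(S(N)(=O)=O)cc2)C2=C(CCCC2)C1c1ccc(Cl)cc1Cl`: 50%

All three share one core and differ only in the group on a saturated ring carbon. Compound 3 stands second highest of the three numbers; the steps that connect it to the others are a number 40 percentage points lower from compound 1 to compound 3 (beyond the scatter) and a number 40 percentage points higher from compound 2 to compound 3 (beyond the scatter), both beyond the scatter.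

Compound 4 `N#CC1=C(N)N(c2ccc(S(N)(=O)=O)cc2)C2=C(CCCC2)C1c1cccs1` carries yet another group at that place: thiophen-2-yl in place of 2,4-dichlorophenyl on a saturated ring carbon. Going by the values given here, no measured compound holds a thiophen-2-yl there, so no measured step bears directly on this change. What the three steps at this position do show is that exchanging the group here moves the number widely: a number 80 percentage points lower from compound 1 to compound 2 (beyond the scatter), a number 40 percentage points lower from compound 1 to compound 3 (beyond the scatter) and a number 40 percentage points higher from compound 2 to compound 3 (beyond the scatter). The direction for compound 4 cannot be read from them, so the expected step is no change at the digits printed from compound 3 to compound 4 (within the scatter), with a wide range. Compound 4 is therefore estimated at 50%, expected between 15% and 85%.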

Compound 4, a percentage reported as activity, at one concentration (the size of the read-out at that concentration, not a potency): 10%
For compound 4 the middle estimate is 40 percentage points above the measured one; the measured number lies below the stated range.
By their numbers in this assay, from the lowest: compounds 2 and 4 (each within the scatter of the next); then compound 3; then compound 1.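

Placing thiophen-2-yl on this saturated ring carbon gives a number 40 percentage points lower from compound 3 to compound 4 (beyond the scatter) in this assay, so the 2,4-dichlorophenyl level is not kept when this five-membered sulfur-containing ring enters. The same group gives no change at the digits printed from compound 2 to compound 4 (within the scatter) and thus sits level with 4-nitrophenyl, showing that two quite different ring groups can give the same low number here, while the step of a number 80 percentage points lower from compound 1 to compound 4 (beyond the scatter) leaves the 2-phenylethenyl of compound 1 far above both. Nothing measured here explains why these groups differ.

The compounds shown leave open whether the low number of compound 4 belongs to the sulfur or to the smaller ring, which a furan-2-yl or an unsubstituted phenyl at this place would help to separate. They also leave open whether the high number of compound 1 needs its phenyl end or would survive with a plain propyl chain.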